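Replacing tert-butyl with 1-methylcyclopropyl: working notes on the series

The source may hold more compounds than are shown below. What is called first, only, known or untested is meant among the compounds shown, and "the series" means these compounds.

Measured so far in an ADME assay for permeability, using PAMPA, at pH 7.4; on this read-out higher numbers stand for higher permeability and lower numbers for lower permeability:
- compound 1 `COc1cc(CN(C)C(=O)c2c(OCCCC3CCN(C(=O)OC(C)(C)C)CC3)c3ccccc3n(C)c2=O)cc(OC)c1`: 295 nm/s
- compound 2 `CCOc1cc(CN(C)C(=O)c2c(OCCCC3CCN(C(=O)OC(C)(C)C)CC3)c3ccccc3n(C)c2=O)cc(OCC)c1`: 275 nm/s
- compound 3 `COc1cc(CN(C)C(=O)c2c(OCCCC3CCN(C(=O)OC(C)(C)C)CC3)c3cccnc3n(C)c2=O)cc(OC)c1`: 241 nm/s

In this assay compound 3 gives 241 nm/s, which lies within the scatter of the values for both compound 1 and compound 2. The next structure is compound 4 `COc1cc(CN(C)C(=O)c2c(OCCCC3CCN(C(=O)OC4(C)CC4)CC3)c3cccnc3n(C)c2=O)cc(OC)c1`, which differs from compound 3 as follows: 1-methylcyclopropyl in place of tert-butyl on an oxygen next to a carbonyl group. In words, 1-methylcyclopropyl stands in place of tert-butyl on an oxygen next to a carbonyl group.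

Among the compounds with values here, the only measured single-place step is a 1.1-fold lower number from compound 1 to compound 2 (0.03 log units; within the scatter). It lies at a different place in the structure and bears only loosely on this change. Within the data shown here, no measured pair varies the group on this oxygen, which leaves the size of the new step without direct support. Across these three compounds, the values stay within the scatter of one another.

The expected result is no step beyond the scatter in this assay, with no direction favoured. The estimated step is a 1.0-fold lower number from compound 3 to compound 4 (0.01 log units; within the scatter). For compound 4 the expected value is 235 nm/s, with an estimated range from 125 nm/s to 420 nm/s.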

Compound 4, apparent permeability: 200 nm/s
Estimate against measurement, compound 4: 1.2-fold (0.07 log units) above; measured number inside the range.
By their numbers in this assay, from the lowest: compounds 4, 3, 2 and 1 (each within the scatter of the next).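

In this assay, within the data shown here, the pair gives the first direct reading at this oxygen: 1-methylcyclopropyl in place of tert-butyl gives a 1.2-fold lower number from compound 3 to compound 4 (0.08 log units; within the scatter). The earlier step concerned the 3,5-dialkoxyphenyl group, so it said nothing about this site; here, closing a three-membered ring of carbon while keeping the count of 4 heavy atoms leaves the read-out within the scatter. No supporting measurement is available to explain the result or to link it to any property of either group.

From the compounds shown here alone, only these two carbon groups have been compared on this oxygen, so the effect of a longer alkyl chain, a primary amine or a carboxylic acid there remains open. Going by these compounds, it is also open whether the same exchange would stay within the scatter on the core of compound 1.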